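From compound 2 to compound 4: chain to ring

The source may report more compounds than this note shows. Statements on the series, on what has been measured and on what is new or still open speak of the compounds shown alone.

Measured in an ADME assay on CEM-SS cells (Homo sapiens) for cytotoxicity, read by XTT assay, with a stated time of 6 days; on this read-out lower numbers stand for higher toxicity in this test and higher numbers for lower toxicity in this test:
Compound 1 `CCCC(=O)OCSc1ccccc1C(=O)NC1(C(N)=O)CCCC1`: > 100 uM
Compound 2 `CCCC(=O)OCSc1ccccc1C(=O)NCCCCC(N)=O`: 51.7 uM
Compound 3 `CCCC(=O)OCSc1ccccc1C(=O)NCCCCCCNC(C)=O`: 8 uM

Compound 2 gives the higher of the two actual numbers in this assay, at 51.7 uM. Compound 3, the nearest, gives 8 uM, which is a 6.5-fold lower number from compound 2 to compound 3 (0.81 log units; beyond the scatter). Compound 1 is reported only as a limit, > 100 uM.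

Compound 4 `CCCC(=O)OCSc1ccccc1C(=O)N[C@@H]1CCC[C@H]1C(N)=O` is still unmeasured. It differs from compound 2 as follows: 2-carbamoylcyclopentyl in place of 4-carbamoylbutyl on an amide-type nitrogen. That is 2-carbamoylcyclopentyl in place of 4-carbamoylbutyl on an amide-type nitrogen.

Among the measured compounds shown here, the closest precedent is compound 1, which also carries a carbamoyl-bearing cyclopentyl group, and its step is an at least 1.9-fold lower number from compound 1 to compound 2 (0.28 log units; that floor lies within the scatter). The larger step, a 6.5-fold lower number from compound 2 to compound 3 (0.81 log units; beyond the scatter), replaces the carbamoyl that compound 4 keeps, so it bears less directly. The expected step is therefore small and toward a higher number, staying within the scatter: a 1.4-fold higher number from compound 2 to compound 4 (0.13 log units; within the scatter). The estimated value for compound 4 is 70 uM, with an expected range of 30 uM to 150 uM.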

Compound 4, half-maximal toxic concentration: 43.7 uM
For compound 4 the middle estimate is 1.6-fold (0.20 log units) above the measured one, and the stated range covers the measured number.
By their numbers in this assay, from the lowest: compound 3; then compounds 4 and 2 (each within the scatter of the next). At a limit, above all of these: compound 1.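

In this assay the step is a 1.2-fold lower number from compound 2 to compound 4 (0.07 log units; within the scatter), so on this amide-type nitrogen the 2-carbamoylcyclopentyl group, with its five-membered carbon ring and 2 defined stereocentres, reads the same as the open 4-carbamoylbutyl chain. The ring alone therefore does not set compound 1 apart, whereas the placement of the carbamoyl on the cyclopentyl group does register: an at least 2.2-fold lower number from compound 1 to compound 4 (0.35 log units; beyond the scatter). That size is only a floor, and the true gap may be larger: the limit of > 100 uM in this assay, at which 1 of the 4 values shown sits.

The compounds shown leave open whether the mirror-image form of the 2-carbamoylcyclopentyl group would read like compound 4 in this assay. They also leave open what a carboxylic acid or an amine in place of the carbamoyl on this ring, or a six-membered carbon ring, would give.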